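A few compounds are considered here, and "the series" means these few. Any claim that something is new, unique, unknown or untested is made for them only; others in the source may bear on it.

In an ADME assay on microsomes from liver (Mus musculus) for metabolic stability, read by mass spectrometry, using NADPH, with a stated time of 60 min (a higher number here means that more of the compound is left, a lower number that less of the compound is left), compound 1 `O=C(CNC1CC1c1cc(F)cc(F)c1OCc1cccnc1F)N1CCC2(CCNC2)CC1`, drawn without configuration at its two stereocentres, gives 73%. For the measured compounds named here, compound 2 `O=C(CN[C@H]1C[C@@H]1c1cc(F)cc(F)c1OCc1cccnc1F)N1CCC2(CCNC2)CC1`, drawn with both stereocentres defined, gives 62%, the lower of the two numbers so far. Compound 3 `O=C(CN[C@@H]1C[C@H]1c1cc(F)cc(F)c1OCc1cccnc1F)N1CCC2(CCNC2)CC1` has not yet been measured. The change from compound 2 is the two compounds have the same atoms and bonds and differ only in configuration as drawn: 2 of 2 stereo elements differ (all stereocentres are inverted: mirror images); a stereocentre at a saturated ring carbon is drawn S in compound 2 and R in compound 3; a stereocentre at a saturated ring carbon is drawn R in compound 2 and S in compound 3; nothing enters or leaves, and the two structures are mirror images.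

Going by the values given here, only one measured step bears on this change: a number 11 percentage points lower from compound 1 to compound 2 (beyond the scatter). It is modest in size and goes with the fact that one of compounds 1 and 2 is drawn with a defined configuration and the other without, at the place where they differ. The drawing of compound 1 does not settle whether it holds both mirror images. If it does, the value of 73% for compound 1 would sit between those of its two components, which would place compound 3 above compound 1. Among the compounds with values here, a rise in this assay is therefore expected rather than no step, somewhat larger than the one measured step, though this rests on a single pair.

The expected step is a number 18 percentage points higher from compound 2 to compound 3 (beyond the scatter). For compound 3, the estimated value is 80%, with an expected range from 62% to 94%.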

Compound 3, percent of the compound remaining: 73%
Estimate against measurement, compound 3: 7 percentage points above; the range from low to high includes it.
By their numbers in this assay, from the lowest: compound 2; then compounds 1 and 3 (each within the scatter of the next).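

The mirror-image pair shows a number 11 percentage points higher from compound 2 to compound 3 (beyond the scatter) in this assay, so configuration alone, with nothing entering or leaving, is enough to shift the percent of compound remaining: the fact that compounds 2 and 3 differ only in the configuration as drawn. Against the compound drawn without configuration, the picture is different, with no change at the digits printed from compound 1 to compound 3 (within the scatter), which places compound 3, and not compound 2, level with compound 1: the fact that one of compounds 1 and 3 is drawn with a defined configuration and the other without, at the place where they differ. Seen beside this, the earlier a number 11 percentage points lower from compound 1 to compound 2 (beyond the scatter) now appears tied to the particular configuration drawn in compound 2, not to defining the stereocentres as such: the fact that one of compounds 1 and 2 is drawn with a defined configuration and the other without, at the place where they differ.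

The drawing of compound 1 still does not settle whether it holds both mirror images, and the numbers in this assay alone cannot decide this. Also open, on these data alone, is whether the gap between the mirror images persists when a methyl group or a carboxylic acid is added to the shared core.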